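The source may report more compounds than this note shows. Statements on the series, on what has been measured and on what is new or still open speak of the compounds shown alone.

Measured compounds and their values:
compound 1, `COc1ccc2c(c1)/C(=C/c1c(-c3ccncc3)nc3sccn13)C(=O)N2C`: 82400 nM
compound 2, `COc1nc2sc(C)cn2c1/C=C1/C(=O)Nc2ccccc21`: 65200 nM
compound 3, `O=C1Nc2ccccc2C1=Cc1c(-c2ccncc2)nc2sccn12`: 82400 nM

All three numbers come from a functional assay on NSCLC cells (Homo sapiens) for cytotoxicity, read by sulforhodamine B assay, with a stated time of 48 h; on this read-out lower numbers stand for stronger inhibition of growth and higher numbers for weaker inhibition of growth. Compound 2 sits with compounds 1 and 3: its gaps to both lie within the usual scatter of repeated measurements, so the three compounds cannot be told apart on these data, and all of them inhibit growth only at high concentrations.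

Compound 4, `COc1nc2sc(C)cn2c1/C=C1/C(=O)Nc2ccc(O)cc21`, has not yet been measured. It differs from compound 2 in one place: hydroxy in place of hydrogen on an aromatic carbon. Among the measured compounds shown here, no pair of measured compounds differs in a single place, so there is no measured step to lean on.

In this assay the step from compound 2 to compound 4 is expected to be small, a 1.3-fold lower number from compound 2 to compound 4 (0.12 log units; within the scatter), with no clear direction beyond the scatter. Compound 4 is therefore estimated at 50000 nM, within a range from 15000 nM to 160000 nM.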

Compound 4, concentration for total growth inhibition: 72000 nM
The estimate for compound 4 lay 1.4-fold (0.16 log units) below the measured number; low and high end bracket the measured number.
By their numbers in this assay, from the lowest: compounds 2, 4, 1 and 3 (each within the scatter of the next).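

In this assay, among the compounds shown here, the hydroxy in place of hydrogen on an aromatic carbon gives a 1.1-fold higher number from compound 2 to compound 4 (0.04 log units; within the scatter) and so provides the first single-place comparison here. Compounds 2 and 4 cannot be told apart, so on these data this position carries a hydroxy group with no detectable effect on growth inhibition. No measured evidence bears on why the step is so small. On these data alone, whether an amine or a carboxylic acid on this same aromatic carbon would separate from compound 2 remains open, as does the effect of hydroxy elsewhere on this ring.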